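This account rests on a few compounds, and the source may have more. Where it says the series, first, only, none or still open, it means among the compounds named here.

Measured so far:
compound 1 `CC(C)[C@H](NC(=S)Nc1cc(C(F)(F)F)cc(C(F)(F)F)c1)c1nc2ccccc2[nH]1` gives 24300 nM in a functional assay on MCF7 cells (Homo sapiens) for cytotoxicity, read by MTT assay; on this read-out higher numbers stand for weaker inhibition and lower numbers for stronger inhibition;
compound 2 `CC(C)C[C@@H](NC(=S)Nc1ccccc1)c1nc2ccccc2[nH]1` gives 11900 nM in this assay;
compound 3 `CC(C)[C@@H](NC(=S)NCc1ccccc1)c1nc2ccccc2[nH]1` gives 11100 nM in this assay.

Among these three numbers compound 2 stands second highest. Its nearest neighbour is compound 3, whose number is within the scatter of it, so the two cannot be told apart; compound 1 lies beyond the scatter, with the weaker number of the two.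

Compound 4 `CC(C)C[C@H](NC(=S)Nc1ccccc1)c1nc2ccccc2[nH]1` is the mirror form of compound 2: the two compounds have the same atoms and bonds and differ only in configuration as drawn: 1 of 1 stereo elements differ; a stereocentre at a saturated chain carbon is drawn R in compound 2 and S in compound 4. Within the data shown here, no measured pair shows the effect of such a change here, so the direction is open; a modest shift either way, or none beyond the scatter, is the expectation. The estimated step of a 1.2-fold higher number from compound 2 to compound 4 (0.07 log units; within the scatter) is therefore small. Compound 4 is expected to give 14000 nM, within 5000 nM to 45000 nM.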

Compound 4, half-maximal inhibitory concentration: 25800 nM
The estimate for compound 4 lay 1.8-fold (0.27 log units) below the measured number; measured number inside the range.
By their numbers in this assay, from the lowest: compounds 3 and 2 (each within the scatter of the next); then compounds 1 and 4 (each within the scatter of the next).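

Configuration at this saturated chain carbon matters in this assay: the R form in compound 2 gives the stronger inhibition, with a 2.2-fold higher number from compound 2 to compound 4 (0.34 log units; beyond the scatter) on going to the S form. Among these compounds, the step is modest, but it is the first beyond the scatter that can be tied to a single change, and it can be set down to configuration alone because of one fact: the fact that compounds 2 and 4 differ only in the configuration as drawn.

As far as these compounds go, whether the R form keeps this edge with other groups on the thiourea stays open. So does the size of the gap between mirror forms carrying a longer chain at this stereocentre.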